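This account rests on a few compounds, and the source may have more. Where it says the series, first, only, none or still open, it means among the compounds named here.

Measured compounds, with their numbers in an assay on RBL-1 cells for inhibition of Polyunsaturated fatty acid 5-lipoxygenase (Rattus norvegicus); a lower number here means a stronger inhibitor, a higher number a weaker inhibitor:
- compound 1, `O=C(/C=C/c1ccc(O)c(O)c1)c1ccc([N+](=O)[O-])cc1`: 23 nM
- compound 2, `Cc1ccc(C(=O)/C=C/c2ccc(O)c(O)c2)cc1`: 76 nM
- compound 3, `COc1ccc(C(=O)/C=C/c2ccc(O)c(O)c2)cc1`: 20 nM

Compound 2 gives the highest of the three numbers in this assay. Its nearest neighbour is compound 1, which lies at a 3.3-fold higher number from compound 1 to compound 2 (0.52 log units; beyond the scatter); the furthest is compound 3, at a 3.8-fold lower number from compound 2 to compound 3 (0.58 log units; beyond the scatter). Compound 1 and compound 3 sit within the scatter of each other, a 1.2-fold lower number from compound 1 to compound 3 (0.06 log units; within the scatter).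

Compound 4, `Cc1ccc(C(=O)/C=C/c2ccc(O)c(O)c2)c(C)c1`, is not yet measured. From compound 2 it differs by methyl in place of hydrogen on an aromatic carbon, that is, a second methyl enters on the ring that already carries one, placed ortho to a large group and meta to the existing methyl group.

Going by the values given here, none of the measured steps adds a group to a hydrogen on this ring; all three exchange the single substituent already there, and those exchanges were modest in size. The shared core of compound 2 is kept intact. Among the compounds with values here, with no step of the same kind on record, the expectation is that compound 4 stays close to compound 2, with any change no larger than the modest steps seen among compound 1, compound 2 and compound 3.

The estimated step is no change at the digits printed from compound 2 to compound 4 (within the scatter), taken as no change beyond the scatter. Compound 4 is therefore expected to give about 76 nM in this assay, within a range of 30 nM to 200 nM.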

Compound 4, half-maximal inhibitory concentration: 17 nM
Compound 4: middle estimate off by 4.5-fold (0.65 log units), on the high side, and the stated range ends above it.
By their numbers in this assay, from the lowest: compounds 4, 3 and 1 (each within the scatter of the next); then compound 2.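

Hydrogen to methyl on the aromatic carbon ortho to a large group and meta to a methyl group is the first addition to this ring in the series, and in this assay it gives a 4.5-fold lower number from compound 2 to compound 4 (0.65 log units; beyond the scatter), so this position accepts a substituent and the number responds to it. Going by these compounds alone, a single added methyl here moves the number about as far as exchanging the existing substituent does in a 3.8-fold lower number from compound 2 to compound 3 (0.58 log units; beyond the scatter), so the ring's substitution pattern matters beyond the one group already present. Nothing at hand bears on what lies behind this step.

As far as these compounds go, whether the same addition lowers the number when the other ring substituent is methoxy or nitro remains open. So does the response at this position to anything other than methyl, such as methoxy, an amine, a carboxylic acid or a longer chain.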